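The source may hold more compounds than are shown below. What is called first, only, known or untested is meant among the compounds shown, and "the series" means these compounds.

Two ureas built on a shared core were examined in a functional assay on HepG2 cells (Homo sapiens) for antiproliferative activity, read by MTT assay; on this read-out lower numbers stand for stronger inhibition and higher numbers for weaker inhibition. Compound 1 `Cc1cccc(NC(=O)Nc2cccc(CNc3ncnc4ccccc34)c2)c1` carries a 3-methylphenyl on its amide-type nitrogen; in this assay compound 1 gives only a limit of the assay, > 50000 nM. Compound 2 `Cc1ccc(NC(=O)Nc2cccc(CNc3ncnc4ccccc34)c2)cc1` carries a 4-methylphenyl in the same place; in this assay compound 2 likewise gives only a limit, > 50000 nM. The step that the two limits leave unreadable from compound 1 to compound 2 therefore cannot be read in either direction, and the two results simply share (the limit of > 50000 nM in this assay, at which 2 of the 2 values shown sit).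

Compound 3 `O=C(Nc1ccc(F)cc1)Nc1cccc(CNc2ncnc3ccccc23)c1` differs from compound 2 in one place: fluoro in place of methyl on an aromatic carbon. The exchange keeps the count of heavy atoms, donors and acceptors unchanged. Among the compounds with values here, no measured step touches a fluoro in place of methyl, and the single measured step is itself unreadable, so nothing in the data points toward a gain or a loss for compound 3 in this assay. Compound 3 is therefore expected to stay near the limit, with a step that the limit leaves unreadable from compound 2 to compound 3 estimated. For compound 3 the estimate is 60000 nM, within an expected range from 10000 nM to 200000 nM.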

Compound 3, half-maximal inhibitory concentration: 41500 nM
Beside the measured number, compound 3's estimate is 1.4-fold (0.16 log units) above it, within the range that was stated.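

In this assay, within the data shown here, compound 3 is the first of the three ureas to give a number rather than a limit, so this position now yields a result that can be read at least in one direction. The change of methyl to fluoro on an aromatic carbon, para to a large group, amounts to an at least 1.2-fold lower number from compound 2 to compound 3 (0.08 log units; that floor lies within the scatter), and the exchange of the 3-methylphenyl for the 4-fluorophenyl amounts to an at least 1.2-fold lower number from compound 1 to compound 3 (0.08 log units; that floor lies within the scatter); both are only floors, since the far end of each step is a limit. Among the three ureas, only compound 3 has a value that stands off that limit: the limit of > 50000 nM in this assay, at which 2 of the 3 values shown sit.

With both floors inside the scatter, the data leave open whether fluoro brings any real gain over methyl here, and how far compound 1 and compound 2 actually lie from compound 3. Going by these compounds, what a chloro, a methoxy or an amine on the same aromatic carbon would give also stays open, as does whether any group there can bring the number well under the limit.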